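Replacing the side chain of compound 3

This account rests on a few compounds, and the source may have more. Where it says the series, first, only, none or still open, it means among the compounds named here.

In an ADME assay on NCM460 cells (Homo sapiens) for cytotoxicity, read by CCK-8 assay, with a stated time of 48 h (on this read-out lower numbers stand for stronger inhibition and higher numbers for weaker inhibition), compound 3 (`COc1ccc(/C=C\c2cc(OC)c(OC)c(OC)c2)cc1OCc1ccc(CNCCN(C)C)cc1`) gives 35000 nM. That value lies within the scatter of compound 1 (`COc1ccc(/C=C\c2cc(OC)c(OC)c(OC)c2)cc1OCc1ccc(C=O)cc1`), which gives 41000 nM. Compound 2 (`COc1ccc(/C=C\c2cc(OC)c(OC)c(OC)c2)cc1OCc1ccc(CN2CCCC[C@@H]2C(=O)O)cc1`) reaches only a limit of the assay, > 50000 nM.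

Compound 4 (`COc1ccc(/C=C\c2cc(OC)c(OC)c(OC)c2)cc1OCc1ccc(CN2CC[C@@H](C(=O)O)C2)cc1`) has not yet been measured. Its difference from compound 3 is 3-carboxypyrrolidin-1-yl in place of (2-(dimethylamino)ethyl)amino on a saturated chain carbon bound to an aromatic carbon. Here, 3-carboxypyrrolidin-1-yl takes the place of (2-(dimethylamino)ethyl)amino on a saturated chain carbon bound to an aromatic carbon.

The nearest guide is compound 2, whose 2-carboxypiperidin-1-yl group also holds a carboxy-bearing ring. The measured step of an at least 1.4-fold lower number from compound 2 to compound 3 (0.15 log units; that floor lies within the scatter) has a floor within the scatter, and both an at least 1.2-fold higher number from compound 1 to compound 2 (0.08 log units; that floor lies within the scatter) and a 1.2-fold lower number from compound 1 to compound 3 (0.07 log units; within the scatter) are similarly small. All three steps therefore point to little movement, with any shift toward higher numbers. The expected step is a 1.4-fold higher number from compound 3 to compound 4 (0.15 log units; within the scatter). The assay may again report only a limit. For compound 4, the estimated value is 50000 nM, with an expected range from 30000 nM to 85000 nM.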

Compound 4, half-maximal inhibitory concentration: > 50000 nM
Compound 4: no number, only a limit (the forecaster's own chance of this, stated with the estimate: 55%); the middle value lies on the limit itself.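

In this assay compound 4 gives a limit and not a number, > 50000 nM. This shows that a second carboxy-bearing ring on this saturated chain carbon, here 3-carboxypyrrolidin-1-yl, ends at the same limit as the 2-carboxypiperidin-1-yl of compound 2: the limit of > 50000 nM in this assay, at which 2 of the 4 values shown sit. The readable steps are an at least 1.4-fold higher number from compound 3 to compound 4 (0.15 log units; that floor lies within the scatter) and an at least 1.2-fold higher number from compound 1 to compound 4 (0.08 log units; that floor lies within the scatter), so neither floor shows a shift beyond the scatter, and the step between compound 2 and compound 4 cannot be read.

As far as these compounds go, how far the true values of these two compounds lie past the limit stays open. Also open, from the compounds shown here alone, is whether the limit goes with the ring or with the carboxylic acid, which a plain pyrrolidin-1-yl on the same carbon would help to separate.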